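The source may hold more compounds than are shown below. What is called first, only, known or untested is meant among the compounds shown, and "the series" means these compounds.

Measured compounds:
- compound 1, `Cc1ccc2nc(N3CCNC(C)C3)nc(NCc3ccc(C(=O)NCc4ccc(F)cc4)cc3)c2c1` — in a functional assay on SW480 cells (Homo sapiens) for inhibition, read by luminescence and resazurin assay, with a stated time of 3 days (a higher number here means a weaker inhibitor, a lower number a stronger inhibitor), compound 1 gives 1400 nM
- compound 2, `CN(C)CCCNc1nc(NCc2ccc(NC(=O)c3ccc(F)cc3)cc2)c2ccccc2n1` — in this assay compound 2 gives 14000 nM

Among the measured compounds shown here, of the two compounds measured so far, compound 1 has the lower number, and its gap to compound 2 is beyond the usual scatter of this kind of measurement. Compound 2 is built on a different core with a different arrangement of the amide, so its value says little about the change considered here beyond the fact that a less potent compound exists in this series.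

The compound not yet measured is compound 3, `Cc1ccc2nc(N(C)C)nc(NCc3ccc(C(=O)NCc4ccc(F)cc4)cc3)c2c1`. It differs from compound 1 in one place: dimethylamino in place of 3-methylpiperazin-1-yl on an aromatic carbon. The ring with its single hydrogen-bond donor is gone, and a small acyclic group takes its place.

For the measured compounds named here, no measured pair shows this exact change, so the size of its effect is unknown. The loss of the ring and of its donor is expected to cost some potency, and the step from compound 1 to compound 3 is estimated to be a 2.5-fold higher number from compound 1 to compound 3 (0.40 log units; beyond the scatter). Compound 3 is therefore expected to give 3500 nM, within a range from 1000 nM to 12000 nM.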

Compound 3, half-maximal inhibitory concentration: 1100 nM
Estimate against measurement, compound 3: 3.2-fold (0.50 log units) above, within the range that was stated.
By their numbers in this assay, from the lowest: compounds 3 and 1 (each within the scatter of the next); then compound 2.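

In this assay, putting dimethylamino in place of 3-methylpiperazin-1-yl on the aromatic carbon between two ring nitrogen atoms gives a 1.3-fold lower number from compound 1 to compound 3 (0.10 log units; within the scatter), so the two compounds cannot be told apart in this test. On this core, then, the number does not depend on keeping the six-membered non-aromatic ring or its hydrogen-bond donor: a smaller group with no ring and no donor gives a value within the scatter of the larger one. No measurement shown here accounts for this result.

Among the compounds shown here, what remains open is how far this lack of response extends, since a single pair shows only that these two groups give matching values at this position, not that any group would. A plain hydrogen, a methoxy group, a morpholine ring or a carboxylic acid on the same carbon would show whether the number stays in place across very different groups or moves once the group attached there through nitrogen is replaced.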